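Swapping the sulfonyl aryl group in a quinoline series

This account rests on a few compounds, and the source may have more. Where it says the series, first, only, none or still open, it means among the compounds named here.

Measured compounds:
- compound 1 `O=S(=O)(c1ccc(F)c(Cl)c1)c1cnc2cc(F)ccc2c1-c1cccc(Cl)c1`: 0.66 mL/min
- compound 2 `O=S(=O)(c1ccc(F)c(Cl)c1)c1cnc2cc(F)ccc2c1-c1cccc(F)c1`: 0.25 mL/min
- compound 3 `O=S(=O)(c1ccc(F)c(Cl)c1)c1cnc2cc(F)ccc2c1-c1ccc(Cl)cc1`: 0.39 mL/min

In an ADME assay on microsomes from liver (Homo sapiens) for metabolic stability, tested at 2.5 uM (a higher number here means faster removal of the compound, a lower number slower removal), compound 2 gives the lowest of the three numbers, sitting within the scatter of compound 3 (a 1.6-fold higher number from compound 2 to compound 3 (0.19 log units; within the scatter)) but clearly apart from compound 1 (a 2.6-fold lower number from compound 1 to compound 2 (0.42 log units; beyond the scatter)). Compound 4 `O=S(=O)(c1cccc(F)c1)c1cnc2cc(F)ccc2c1-c1cccc(F)c1` has not been measured. It differs from compound 2 by 3-fluorophenyl in place of 3-chloro-4-fluorophenyl on a sulfonyl sulfur. Within the data shown here, no measured step touches the group on the sulfonyl sulfur, so direct guidance is lacking. Among the measured compounds shown here, the only step that also removes a chlorine, from compound 1 to compound 2, was modest and downward. A similar or smaller shift is therefore expected in this assay, a 1.3-fold lower number from compound 2 to compound 4 (0.10 log units; within the scatter). Compound 4 is estimated at 0.2 mL/min, with a range from 0.08 mL/min to 0.5 mL/min.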

Compound 4, intrinsic clearance in a liver preparation (reported as CLH), per the amount of preparation that the assay uses: 0.24 mL/min
Compound 4: middle estimate off by 1.2-fold (0.08 log units), on the low side; the measured number falls inside the stated range.
By their numbers in this assay, from the lowest: compounds 4, 2, 3 and 1 (each within the scatter of the next, the first and the last beyond it).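

This first change at the sulfonyl sulfur, 3-fluorophenyl in place of 3-chloro-4-fluorophenyl, gives in this assay a 1.0-fold lower number from compound 2 to compound 4 (0.02 log units; within the scatter) and so no readable shift. With the rest of compound 2 unchanged, this group can therefore lose its chlorine and one fluorine position without moving the number beyond the scatter. Nothing available explains this result.

Still open, on these data alone, is how a group without a phenyl ring, such as an amine or a carboxylic acid, would behave on the sulfonyl sulfur. Also open, as far as these compounds go, is whether this same swap would read alike on compound 1 or compound 3.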